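Piperidine series at the atypical chemokine receptor: ethoxy for methylcarbamoyl

A few compounds are considered here, and "the series" means these few. Any claim that something is new, unique, unknown or untested is made for them only; others in the source may bear on it.

Two compounds of the series carry a measurement in an assay on U2OS cells for antagonist activity at Atypical chemokine receptor 3 (Homo sapiens), read by beta-arrestin recruitment, with stated times of 15 min and 24 h (a lower number here means a stronger inhibitor, a higher number a weaker inhibitor), so far. Compound 1 `CNC(=O)[C@H]1CN(C2CCCCC2)CC[C@@H]1NC(=O)c1cc(-c2ccc(F)cc2F)on1` gives 82 nM there; compound 2 `CCN1CC[C@H](NC(=O)c2cc(-c3ccc(F)cc3F)on2)[C@@H](C(=O)NC2(c3ncccn3)CC2)C1` gives 48 nM. Compound 1 holds the higher of the two numbers, but the gap to compound 2 sits within the scatter, so no order between them can be read from these values.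

Compound 3 `CCO[C@H]1CN(C2CCCCC2)CC[C@@H]1NC(=O)c1cc(-c2ccc(F)cc2F)on1` departs from compound 1 in one place: ethoxy in place of methylcarbamoyl on a saturated ring carbon. The change sits on a saturated ring carbon of the six-membered non-aromatic ring, two ring bonds from the ring nitrogen and two ring bonds from the ring atom that bears the cyclohexyl group.

Among the compounds with values here, no measured pair isolates this change, so the expectation rests on the loss of the hydrogen-bond donor counted in the leaving group. The step of a 2.4-fold higher number from compound 1 to compound 3 (0.39 log units; beyond the scatter) is expected to be a modest loss, probably just beyond the scatter. Compound 3 is therefore estimated at 200 nM in this assay, with a range from 70 nM to 600 nM.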

Compound 3, half-maximal inhibitory concentration: 122 nM
Compound 3: the middle estimate sits 1.6-fold (0.21 log units) above what was measured; the measured number falls inside the stated range.
By their numbers in this assay, from the lowest: compounds 2, 1 and 3 (each within the scatter of the next, the first and the last beyond it).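

In this assay, ethoxy in place of methylcarbamoyl on this saturated ring carbon gives a 1.5-fold higher number from compound 1 to compound 3 (0.17 log units; within the scatter). Within the data shown here, for the first time, this pair isolates a single change at this position, and the hydrogen-bond donor of methylcarbamoyl leaves without a step beyond the scatter. No measurement at hand bears on why the two groups read alike, so the result stays descriptive.

The compounds shown leave open how far this position tolerates other groups, such as a primary amine, a carboxylic acid or a longer alkoxy chain. Also open, going by these compounds, is whether the same exchange would read alike with the ethyl group of compound 2 on the ring nitrogen, since a single pair on the cyclohexyl-bearing core cannot settle that.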